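Aryl Group Replaces Hydroxyalkyl: Expected Cytotoxicity of Compound 3

The source may hold more compounds than are shown below. What is called first, only, known or untested is meant among the compounds shown, and "the series" means these compounds.

Measured compounds in a functional assay on HCT-116 cells (Homo sapiens) for cytotoxicity, read by MTT assay, with a stated time of 72 h; a lower number here means a stronger inhibitor, a higher number a weaker inhibitor:
compound 1, `NC(=O)c1cn(Cc2nnc(-c3cc(S(N)(=O)=O)c(SCc4ccccc4)cc3Cl)o2)nn1`: 72000 nM
compound 2, `CC(C)(O)c1cn(Cc2nnc(-c3cc(S(N)(=O)=O)c(SCc4ccccc4)cc3Cl)o2)nn1`: 82000 nM

Going by the values given here, compound 2 holds the highest of the two numbers in this assay, with compound 1 nearest to it; the only step recorded, a 1.1-fold higher number from compound 1 to compound 2 (0.06 log units; within the scatter), lies within the scatter. Compound 3, `COc1ccc(-c2cn(Cc3nnc(-c4cc(S(N)(=O)=O)c(SCc5ccccc5)cc4Cl)o3)nn2)cc1`, differs from compound 2 by 4-methoxyphenyl in place of 1-hydroxy-1-methylethyl on an aromatic carbon. Among the compounds with values here, no measured step touches this position with a change of this kind, so nothing argues for a shift beyond the scatter in either direction. Compound 3 is therefore expected to give about 65000 nM, between 25000 nM and 180000 nM. The expected step is a 1.3-fold lower number from compound 2 to compound 3 (0.10 log units; within the scatter).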

Compound 3, half-maximal inhibitory concentration: 190000 nM
Estimate against measurement, compound 3: 2.9-fold (0.47 log units) below; the whole stated range lies below it.
By their numbers in this assay, from the lowest: compounds 1 and 2 (each within the scatter of the next); then compound 3.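

In this assay, this position proved able to move the number: carbamoyl and 1-hydroxy-1-methylethyl had stayed within the scatter of each other, whereas 4-methoxyphenyl gives a 2.3-fold higher number from compound 2 to compound 3 (0.36 log units; beyond the scatter) and a 2.6-fold higher number from compound 1 to compound 3 (0.42 log units; beyond the scatter). Against 1-hydroxy-1-methylethyl, the change adds a six-membered aromatic ring of carbon only and removes a hydrogen-bond donor, and this single compound cannot separate those two differences. Nothing available accounts for the rise. As far as these compounds go, it remains open whether a plain phenyl group would behave like 4-methoxyphenyl, and how an amine or a carboxylic acid at this position would read.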